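The source may hold more compounds than are shown below. What is called first, only, known or untested is meant among the compounds shown, and "the series" means these compounds.

Compound 2 is `CCN(CC)c1ccc2cc(C(=O)c3ccc(N4CCN(S(=O)(=O)c5ccc(F)cc5)CC4)cc3)oc2c1`, and compound 1, `CCOC(=O)N1CCN(c2ccc(C(=O)c3cc4ccc(N(CC)CC)cc4o3)cc2)CC1`, differs from it in one place. In a functional assay on SGC-7901 cells (Homo sapiens) for cytotoxicity, read by MTT assay, with a stated time of 48 h (a lower number here means a stronger inhibitor, a higher number a weaker inhibitor), compound 1 gives > 40000 nM, which is a limit of the assay rather than a number. Compound 2 gives > 40000 nM in this assay, again a limit and not a number. Among the measured compounds shown here, the one measured step, a step that the two limits leave unreadable from compound 1 to compound 2, cannot be read because of the limit of > 40000 nM in this assay, at which 2 of the 2 values shown sit. Compound 2 therefore stands at the edge of what this assay can report, with no number of its own. Compound 3 is `CCN(CC)c1ccc2cc(C(=O)c3ccc(N4CCN(S(=O)(=O)c5ccc(Br)c(F)c5)CC4)cc3)oc2c1`. It differs from compound 2 in one place: 4-bromo-3-fluorophenyl in place of 4-fluorophenyl on a sulfonyl sulfur. For the measured compounds named here, the only measured step in this region of the shared core is the unreadable one, so no measured step says in which direction this change should move the number, or by how much. Compound 3 is expected to stay near the same edge, with an estimated step of a number no higher from compound 2 to compound 3 (the limit leaves the size open). The estimate for compound 3 in this assay is 40000 nM, within a range from 15000 nM to 100000 nM.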

Compound 3, half-maximal inhibitory concentration: > 40000 nM
Compound 3 was reported as a limit; the forecaster's own chance of this, stated with the estimate: 75%; the middle value lies on the limit itself.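

In this assay compound 3 gives > 40000 nM, a limit and not a number. Among the compounds shown here, no step among compound 1, compound 2 and compound 3 can be read, because all three sit at the same edge: the limit of > 40000 nM in this assay, at which 3 of the 3 values shown sit. The compounds shown leave open whether these groups on the shared core differ in strength at all.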